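Swapping pentan-3-yl for cyclopropyl in compound 2

This account rests on a few compounds, and the source may have more. Where it says the series, first, only, none or still open, it means among the compounds named here.

In an ADME assay on microsomes from liver (Rattus norvegicus) for metabolic stability (on this read-out lower numbers stand for a shorter-lived compound and higher numbers for a longer-lived compound), compound 1 `CC(C)C(c1ccc(-c2ccc3cccc(F)c3c2)[nH]c1=O)C1NC(=O)NC1=O` gives 0.145 h. Compound 2 `CCC(CC)C(/C=C1\OC(=O)NC1=O)c1ccc(-c2ccc3cccc(F)c3c2)[nH]c1=O` reads > 3 h, which is a limit of the assay and not a number. Compound 3 `C/C(=C1/OC(=O)NC1=O)C(c1ccc(-c2ccc3cccc(F)c3c2)[nH]c1=O)C(C)C` reads > 3 h, which is also a limit. Compound 2 therefore stands at the limit of > 3 h in this assay, at which 2 of the 3 values shown sit, and has no exact number of its own.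

Compound 4 `O=C1NC(=O)/C(=C/C(c2ccc(-c3ccc4cccc(F)c4c3)[nH]c2=O)C2CC2)O1` differs from compound 2 by cyclopropyl in place of pentan-3-yl on a saturated chain carbon bound to an aromatic carbon and a double-bonded chain carbon. That is, cyclopropyl stands in place of pentan-3-yl on a saturated chain carbon bound to an aromatic carbon and a double-bonded chain carbon. Within the data shown here, no measured step varies this group alone. Among the measured compounds shown here, the only measured step, an at least 20-fold higher number from compound 1 to compound 3 (1.31 log units; beyond the scatter), is large and beyond the scatter, but it exchanges one five-membered ring group for another. Compound 4 keeps the ring group that entered in that step, so it is expected to remain long-lived in this assay. The expected step is a number no higher from compound 2 to compound 4 (the limit leaves the size open), which would be no change beyond the scatter. For compound 4 the estimated half-life is 3 h, with an expected range from 1 h to 6 h.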

Compound 4, half-life: > 3 h
Compound 4: no number, only a limit (the forecaster's own chance of this, stated with the estimate: 55%); the middle value sits exactly at the limit.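

In this assay, among these compounds, compound 4 reads > 3 h, a limit and not a number, as is the reading for compound 2, so no step between compound 2 and compound 4 can be read. The compounds shown leave open whether cyclopropyl in place of pentan-3-yl changes the half-life at all.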